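The source may hold more compounds than are shown below. What is called first, only, known or untested is meant among the compounds shown, and "the series" means these compounds.

Compound 2 `N[C@@H]1CCCN(c2cc(NCc3ccc(Cl)cc3Cl)n3nccc3n2)C1` stands, in an assay on isolated protein for inhibition of Dipeptidyl peptidase 9 (Homo sapiens) (a lower number here means a stronger inhibitor, a higher number a weaker inhibitor), at > 100000 nM, which is a limit of the assay rather than a number. Compound 1 `Cc1ccnc(Nc2cc(N3CCC[C@@H](N)C3)nc3ccnn23)c1` likewise gives > 100000 nM in this assay, again a limit. Compound 3 `Fc1ccc(CNc2cc(N3CCNCC3)nc3ccnn23)c(F)c1` gives > 50000 nM, also a limit. Every value shown is therefore a limit: the limit of > 100000 nM in this assay, at which 2 of the 3 values shown sit, and (the limit of > 50000 nM in this assay, at which 1 of the 3 values shown sits). Compound 4 `N[C@@H]1CCCN(c2cc(NCc3ccc(O)cc3)n3nccc3n2)C1` differs from compound 2 by 4-hydroxyphenyl in place of 2,4-dichlorophenyl on a saturated chain carbon bound to a nitrogen on an aromatic ring. For the measured compounds named here, no step between measured compounds is available to guide this change, and every neighbour of compound 4 sits at a limit, so no step beyond the scatter is expected in either direction, and compound 4 is expected to remain near the limit as well, with the expected step from compound 2 to compound 4 being a number no higher from compound 2 to compound 4 (the limit leaves the size open). For compound 4 the estimate is 100000 nM, within 30000 nM to 300000 nM.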

Compound 4, half-maximal inhibitory concentration: > 50000 nM
Compound 4 gave a limit, no number; the forecaster's own chance of this, stated with the estimate: 85%; the middle value does not contradict the limit.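

For the compounds shown here, compound 4, like compound 1 and compound 2, gives only a limit, and no step from either of them to compound 4 can be read. The compounds shown leave open whether swapping 2,4-dichlorophenyl for 4-hydroxyphenyl changes inhibition at all.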